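Replacing a methoxy with a hydroxy in cytotoxic compounds

The source may hold more compounds than are shown below. What is called first, only, known or untested is meant among the compounds shown, and "the series" means these compounds.

In a functional assay on SW-620 cells (Homo sapiens) for cytotoxicity, read by MTT assay, with a stated time of 72 h (on this read-out higher numbers stand for weaker inhibition and lower numbers for stronger inhibition), compound 3 `COc1ccc(/C=C2\CCC/C(=C\c3ccc(OC)c(OC)c3)C2=O)cc1` gives 6600 nM and so sits within the scatter of compound 1 `COc1ccc(/C=C2\CCC/C(=C\c3ccc(Cl)cc3)C2=O)cc1OC` at 5900 nM and of compound 2 `COc1cccc(/C=C2\CCC/C(=C\c3ccc(OC)c(OC)c3)C2=O)c1` at 3700 nM without a clear place among them.

Compound 4 `COc1ccc(/C=C2\CCC/C(=C\c3ccc(O)cc3)C2=O)cc1OC` awaits measurement. It differs from compound 3 by a single change hydrogen in place of methyl on an oxygen on an aromatic ring in which hydrogen takes the place of methyl on an oxygen on an aromatic ring, so 4-methoxyphenyl becomes 4-hydroxyphenyl.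

For the measured compounds named here, no measured step makes this exact change. The nearest guide is methoxy in place of chloro on an aromatic carbon, which gave a 1.1-fold higher number from compound 1 to compound 3 (0.05 log units; within the scatter) and the swap of 3-methoxyphenyl for 4-methoxyphenyl gave a 1.8-fold higher number from compound 2 to compound 3 (0.25 log units; within the scatter) as well. As far as these compounds go, neither step left the scatter, so no step beyond it is expected in this assay here, and the direction stays open. The estimated step is a 1.3-fold lower number from compound 3 to compound 4 (0.12 log units; within the scatter) and it is only a small one.

For compound 4 the expected value is 5000 nM with an estimated range from 2000 nM at the low end to 11000 nM at the high end.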

Compound 4, half-maximal inhibitory concentration: 7700 nM
Estimate against measurement, compound 4: 1.5-fold (0.19 log units) below; the measured number falls inside the stated range.
By their numbers in this assay, from the lowest: compounds 2, 1, 3 and 4 (each within the scatter of the next, the first and the last beyond it).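

Within this assay, the step of a 1.2-fold higher number from compound 3 to compound 4 (0.07 log units; within the scatter) shows that hydrogen in place of methyl on this oxygen, turning 4-methoxyphenyl into 4-hydroxyphenyl, leaves the number within the scatter. The step of a 1.3-fold higher number from compound 1 to compound 4 (0.12 log units; within the scatter) likewise stays within the scatter, so hydroxy and chloro on this aromatic carbon cannot be told apart here. For the compounds shown here, the step of a 2.1-fold higher number from compound 2 to compound 4 (0.32 log units; beyond the scatter) is the first in this set to pass beyond the scatter, though only modestly, and it swaps 3-methoxyphenyl for 4-hydroxyphenyl, so the change involves more than the oxygen's methyl alone.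

Still open, as far as these compounds go, is whether an amine or a carboxylic acid on this aromatic carbon would shift the number clearly. Nothing measured here explains why these steps are so small.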